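Halogen pattern on the sulfonamide aryl ring and receptor binding

The compounds below may be only part of what the source reports. "The series", "measured", "known", "first", "only" and "open" are said of these compounds alone.

Measured compounds:
compound 1 `COc1ccc(S(=O)(=O)Nc2cccc(Br)c2)cc1N1CCNCC1` — 1.26 nM
compound 2 `COc1ccc(S(=O)(=O)Nc2cc(Br)cc(Br)c2)cc1N1CCNCC1` — 0.501 nM
compound 3 `COc1ccc(S(=O)(=O)Nc2cc(Cl)c(Cl)cc2Cl)cc1N1CCNCC1` — 5.01 nM

All three share one core and differ only in the ring attached to the sulfonamide nitrogen. In an assay on isolated protein for binding affinity to 5-hydroxytryptamine receptor 6 (Homo sapiens) (a lower number here means a stronger inhibitor, a higher number a weaker inhibitor), compound 3 stands highest of the three numbers; its nearest neighbour is compound 1, as seen in a 4.0-fold higher number from compound 1 to compound 3 (0.60 log units; beyond the scatter), and its furthest is compound 2, as seen in a 10-fold higher number from compound 2 to compound 3 (1.00 log units; beyond the scatter). Compound 4 `COc1ccc(S(=O)(=O)Nc2cc(Br)cc(Br)c2Cl)cc1N1CCNCC1` is not yet measured. The change from compound 3 to compound 4 is 3,5-dibromo-2-chlorophenyl in place of 2,4,5-trichlorophenyl on a sulfonamide nitrogen. For the measured compounds named here, two measured steps bear on it: a 2.5-fold lower number from compound 1 to compound 2 (0.40 log units; beyond the scatter) shows that adding a second bromo to the ring gave a lower number, and a 10-fold higher number from compound 2 to compound 3 (1.00 log units; beyond the scatter) shows that the 2,4,5-trichlorophenyl ring gave a clearly higher number than 3,5-dibromophenyl. Compound 4 carries the 3,5-dibromo pattern of compound 2 together with one chloro, so a number between those of compound 2 and compound 3 is expected, meaning a lower number than compound 3 in this assay, a step of a 3.3-fold lower number from compound 3 to compound 4 (0.52 log units; beyond the scatter). Compound 4 is therefore estimated at 1.5 nM, with a range from 0.4 nM to 6 nM.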

Compound 4, inhibition constant: 2.51 nM
The estimate for compound 4 lay 1.7-fold (0.22 log units) below the measured number; the measured number falls inside the stated range.
By their numbers in this assay, from the lowest: compound 2; then compounds 1, 4 and 3 (each within the scatter of the next, the first and the last beyond it).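

In this assay, the exchange of 2,4,5-trichlorophenyl for 3,5-dibromo-2-chlorophenyl on a sulfonamide nitrogen gives a 2.0-fold lower number from compound 3 to compound 4 (0.30 log units; within the scatter) and so does not separate these two rings, even though both carry chloro and differ in their other halogens. The single added chloro matters more, with a 5.0-fold higher number from compound 2 to compound 4 (0.70 log units; beyond the scatter) showing that it costs binding on the 3,5-dibromophenyl ring, while a 2.0-fold higher number from compound 1 to compound 4 (0.30 log units; within the scatter) leaves the fully substituted ring not separable from the 3-bromophenyl ring. Nothing measured here accounts for these shifts.

As far as these compounds go, how a nitrile or a carboxylic acid in place of that chloro would read in this assay stays open. So does whether a fluoro there would cost as much as the chloro does.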